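The source may hold more compounds than are shown below. What is called first, only, known or untested is meant among the compounds shown, and "the series" means these compounds.

Measured compounds:
compound 1 `CN(C)CCn1cnnc1-c1cc(Oc2ccc(NC(=O)N/N=C/c3ccc(Cl)cc3Cl)cc2F)ccn1` — 810 nM
compound 2 `CN(C)CCn1cnnc1-c1cc(Oc2ccc(NC(=O)N/N=C/c3cccc(Cl)c3Cl)cc2F)ccn1` — 1090 nM

In a functional assay on A549 cells (Homo sapiens) for cytotoxicity, read by MTT assay, with a stated time of 72 h (a higher number here means a weaker inhibitor, a lower number a stronger inhibitor), compound 1 gives 810 nM and compound 2 gives 1090 nM. For the measured compounds named here, compound 2 carries the higher of the two numbers, but the only measured step, a 1.3-fold higher number from compound 1 to compound 2 (0.13 log units; within the scatter), is within the scatter, so the two compounds cannot be told apart on these data.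

Compound 3 `CN(C)CCn1cnnc1-c1cc(Oc2ccc(NC(=O)N/N=C/c3c(O)ccc4ccccc34)cc2F)ccn1` is the next compound. Its change from compound 2 is 2-hydroxynaphthalen-1-yl in place of 2,3-dichlorophenyl on a carbon with a double bond to nitrogen. Going by the values given here, the one measured step concerns only a move of chlorine atoms on the same ring and bears little on this larger replacement, so the expectation rests mainly on compound 2 and its value 1090 nM. The estimated step of a 1.1-fold lower number from compound 2 to compound 3 (0.04 log units; within the scatter) is therefore expected to be small, with no firm direction and a wide range. Compound 3 is estimated at 1000 nM, expected between 250 nM and 4000 nM.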

Compound 3, half-maximal inhibitory concentration: 880 nM
For compound 3 the middle estimate is 1.1-fold (0.06 log units) above the measured one; the range from low to high includes it.
By their numbers in this assay, from the lowest: compounds 1, 3 and 2 (each within the scatter of the next).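

In this assay, the step of a 1.2-fold lower number from compound 2 to compound 3 (0.09 log units; within the scatter) and the step of a 1.1-fold higher number from compound 1 to compound 3 (0.04 log units; within the scatter) show that this position, on a carbon with a double bond to nitrogen, accommodates a much larger replacement than the earlier move of chlorine atoms on one ring without leaving the scatter. The entering 2-hydroxynaphthalen-1-yl has a second six-membered aromatic ring of carbon only, a hydrogen-bond donor and no chlorine, yet compounds 1, 2 and 3 cannot be told apart on these numbers. No measurement is available to explain this. From the compounds shown here alone, the hydroxyl group and the second ring enter together, so their separate contributions remain unknown, and naphthalen-1-yl without the hydroxyl would be needed to separate them. Going by these compounds, whether an aliphatic amine or a carboxylic acid on the ring at this position would also stay within the scatter remains open.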